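Isopropoxy in Place of Hydrogen on Compound 1

The source may hold more compounds than are shown below. What is called first, only, known or untested is meant among the compounds shown, and "the series" means these compounds.

Compound 1 `O=C(O)c1cnc(-c2ccccc2)[nH]c1=O` is the parent of a small set tested in a functional assay on the whole organism (strain Sprague-Dawley) for inhibition, with Rattus norvegicus as the target, with a stated time of 10 min (a higher number here means that more compound is needed for the effect, a lower number that less compound is needed), where compound 1 gives 50 mg/kg. This is the highest of the two readable numbers; the nearest is compound 2 `O=C(O)c1cnc(-c2ccccc2Cl)[nH]c1=O`, which gives 5 mg/kg, so the step of a 10-fold lower number from compound 1 to compound 2 (1.00 log units; beyond the scatter) is a clear gain. Compound 3 `O=C(O)c1cnc(-c2ccccc2O)[nH]c1=O` gives only a limit of the assay, > 5 mg/kg. The step that the limit leaves unreadable from compound 1 to compound 3 cannot be sized because compound 3 sits at the limit of > 5 mg/kg in this assay, at which 1 of the 3 values shown sits, and the same holds for a number no lower from compound 2 to compound 3 (the limit leaves the size open).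

Compound 4 `CC(C)Oc1ccccc1-c1ncc(C(=O)O)c(=O)[nH]1` differs from compound 1 by isopropoxy in place of hydrogen on an aromatic carbon. Within the data shown here, the only readable step that bears on a new group at this aromatic carbon is a 10-fold lower number from compound 1 to compound 2 (1.00 log units; beyond the scatter); the hydroxy step gives no size. Among the measured compounds shown here, a lowering is therefore expected, though a smaller one than for chloro, since no measured step speaks for this larger group. Compound 4 is estimated at 15 mg/kg, within a range from 3 mg/kg to 60 mg/kg, which means an expected step of a 3.3-fold lower number from compound 1 to compound 4 (0.52 log units; beyond the scatter).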

Compound 4, dose for 50% inhibition: 0.8 mg/kg
Beside the measured number, compound 4's estimate is 19-fold (1.27 log units) above it; the whole stated range lies above it.
By their numbers in this assay, from the lowest: compound 4; then compound 2; then compound 1.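

At this place on the aromatic ring, chloro does not mark the limit of what the position can give: isopropoxy produces a 63-fold lower number from compound 1 to compound 4 (1.80 log units; beyond the scatter), the largest step seen from compound 1 in this assay, and it also goes further than chloro, with a 6.3-fold lower number from compound 2 to compound 4 (0.80 log units; beyond the scatter). The group on the oxygen matters as well, since isopropyl in place of the hydrogen on that oxygen gives an at least 6.2-fold lower number from compound 3 to compound 4 (0.79 log units; beyond the scatter). This last step stays open at one end, as compound 3 gives only a limit of the assay: the limit of > 5 mg/kg in this assay, at which 1 of the 4 values shown sits.

The compounds shown leave open whether the gain depends on the oxygen or on the branched chain, which methoxy, ethoxy or an isopropyl set directly on the ring could separate. As far as these compounds go, how a longer chain or an amine would behave at this place also remains unknown.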